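The source may hold more compounds than are shown below. What is called first, only, known or untested is meant among the compounds shown, and "the series" means these compounds.

Working notes on the series. Compound 1 `CCCCNc1nc(N)nc2c1CN(C)CC2` gives 0.03 uM in an assay on HEK293 cells for agonist activity at Toll-like receptor 8 (Homo sapiens), read by a luciferase reporter, with a stated time of 6 h; on this read-out higher numbers stand for an effect only at larger amounts of compound and lower numbers for an effect already at smaller amounts. Compound 2 `CCCCNc1nc(N)nc2c1CN(C(=O)c1ccccc1)CC2` gives 1.4 uM in this assay, and compound 3 `CCCCNc1nc(N)nc2c1CN(C(=O)CC)CC2` gives 0.4 uM. Compound 3 thus stands second highest of the three numbers: nearest to it is compound 2, a 3.5-fold lower number from compound 2 to compound 3 (0.54 log units; beyond the scatter); furthest is compound 1, a 13-fold higher number from compound 1 to compound 3 (1.12 log units; beyond the scatter), with a 47-fold higher number from compound 1 to compound 2 (1.67 log units; beyond the scatter) as the largest step seen so far.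

The next compound is compound 4 `CCCCNc1nc(N)nc2c1CN(C(=O)c1cocn1)CC2`. Its difference from compound 3 is 1,3-oxazol-4-yl in place of ethyl on a carbonyl carbon. Among the compounds with values here, the step that bears on this is the one between compound 2 and compound 3, where ethyl in place of phenyl on the carbonyl carbon gave a 3.5-fold lower number from compound 2 to compound 3 (0.54 log units; beyond the scatter). The present change runs the other way, from ethyl to a five-membered aromatic ring with two hetero atoms, so a higher number is expected, of modest size. Within the data shown here, whether the two hydrogen-bond acceptors of 1,3-oxazol-4-yl shift this further cannot be read from the three compounds measured, as no other step in the set involves such a ring.

For compound 4 the expected step is a 3.0-fold higher number from compound 3 to compound 4 (0.48 log units; beyond the scatter). The estimated value for compound 4 is 1.2 uM, with a range from 0.4 uM to 4 uM.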

Compound 4, minimum effective concentration: 0.2 uM
For compound 4 the middle estimate is 6.0-fold (0.78 log units) above the measured one; the measured number lies below the stated range.
By their numbers in this assay, from the lowest: compound 1; then compounds 4 and 3 (each within the scatter of the next); then compound 2.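

In this assay, an aromatic ring on the carbonyl carbon does not in itself carry the higher number seen with compound 2: 1,3-oxazol-4-yl in place of ethyl gives (a 2.0-fold lower number from compound 3 to compound 4 (0.30 log units; within the scatter)), so these two groups stand level at this position. Against phenyl, the same change gives (a 7.0-fold lower number from compound 2 to compound 4 (0.85 log units; beyond the scatter)), which shows that the two aromatic rings are not interchangeable here, something the step from phenyl to ethyl alone could not reveal. The (1,3-oxazol-4-yl)carbonyl group still does not reach the methyl of the core of compound 1 (a 6.7-fold higher number from compound 1 to compound 4 (0.82 log units; beyond the scatter)), so all three compounds with a carbonyl on this ring nitrogen lie above compound 1, and none of the shown compounds goes against this.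

Nothing at hand gives a reason for the separation of 1,3-oxazol-4-yl from phenyl. Open, from the compounds shown here alone, is whether a pyridin-2-yl group on the carbonyl carbon would follow phenyl or 1,3-oxazol-4-yl, and whether a benzyl group directly on the amine nitrogen would keep the low number of compound 1 or move towards the compounds with a carbonyl there.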